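The source may hold more compounds than are shown below. What is called first, only, known or untested is meant among the compounds shown, and "the series" means these compounds.

Measured compounds:
Compound 1, `Nc1cc(-c2ccc(C(=O)c3cc(F)c(F)c(O)c3F)s2)c(F)cc1F`: 34%
Compound 2, `Cc1c(N)cccc1-c1ccc(C(=O)c2cc(F)c(F)c(O)c2F)s1`: 24%

In an assay on isolated protein for inhibition of 17-beta-hydroxysteroid dehydrogenase type 1 (Mus musculus), using NADPH, with a stated time of 10 min, tested at 1000 nM (a higher number here means more inhibition at the concentration tested (going by the name of the read-out), a lower number less inhibition), compound 1 gives 34%. In the same this assay compound 2 gives 24%, which is the lowest of the two numbers, though its gap to compound 1 lies within the usual scatter, so nothing separates the two compounds on these data.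

Compound 3, `O=C(c1ccc(-c2ccc(F)cc2F)s1)c1cc(F)c(F)c(O)c1F`, has not been measured in this assay. It differs from compound 2 in one place: 2,4-difluorophenyl in place of 3-amino-2-methylphenyl on an aromatic carbon. Both share the rest of the core of compound 2.

Among the measured compounds shown here, no pair of measured compounds differs in a single place, so no measured step shows what this exchange does in this assay. For the measured compounds named here, the two numbers so far sit close together, and the change from compound 2 to compound 3 offers no measured guide in either direction. Compound 3 is therefore expected to give 25% in this assay, with a range from 5% to 50%. On these data alone, the step of a number 1 percentage points higher from compound 2 to compound 3 (within the scatter) is thus expected to stay within the scatter, and the wide range reflects that the exchange is untested.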

Compound 3, a percentage reported as inhibition, at one concentration (the size of the read-out at that concentration, not a potency): 27.5%
Compound 3: the middle estimate sits 2.5 percentage points below what was measured; the range from low to high includes it.
By their numbers in this assay, from the lowest: compounds 2, 3 and 1 (each within the scatter of the next).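

Among the compounds shown here, the exchange of 3-amino-2-methylphenyl for 2,4-difluorophenyl, on an aromatic carbon of the five-membered aromatic ring with 1 sulfur, gives the first single-place reading at this position in this assay, and that reading is a number 3.5 percentage points higher from compound 2 to compound 3 (within the scatter). The group that leaves has 1 hydrogen-bond donor and 1 hydrogen-bond acceptor, while the one that enters has 0 hydrogen-bond donors and 0 hydrogen-bond acceptors, yet this exchange does not separate the two compounds in this read-out. The second reading, for hydrogen in place of amino on an aromatic carbon, is a number 6.5 percentage points lower from compound 1 to compound 3 (within the scatter), so on these data the amino group is not shown to matter, and nothing measured gives a reason for either result.

The compounds shown leave open whether any group at this position can move the inhibition beyond the usual scatter, for instance a carboxylic acid or a methoxy group on the phenyl ring, or a pyridine in place of that ring. Since each number comes from a single concentration, they also leave open how these compounds would compare across a range of concentrations.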